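Swapping a fluorobenzyl amide for methylpiperazine: cytotoxicity outlook

The compounds below may be only part of what the source reports. "The series", "measured", "known", "first", "only" and "open" are said of these compounds alone.

Compound 1 `CS(=O)(=O)c1ccc(C(=O)N2CCC(C(=O)N3CCN(c4ccc(F)cc4)CC3)CC2)cc1[N+](=O)[O-]` gives in an ADME assay on HepG2 cells (Homo sapiens) for cytotoxicity, read by CellTiter-Glo and ATP content, with a stated time of 72 h; on this read-out lower numbers stand for an effect already at smaller amounts and higher numbers for an effect only at larger amounts of compound > 27000 nM, which is a limit of the assay and not a number.
Compound 2 `CN(Cc1ccccc1)C(=O)C1CCN(C(=O)c2ccc(S(C)(=O)=O)c([N+](=O)[O-])c2)CC1` gives in this assay > 27000 nM, again a limit rather than a number.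
Compound 3 `CN(Cc1ccccc1F)C(=O)C1CCN(C(=O)c2ccc(S(C)(=O)=O)c([N+](=O)[O-])c2)CC1` gives in this assay > 27000 nM, also only a limit.

Compound 3 therefore stands at the limit of this assay, and no measured number places it apart from the other two compounds; the limit of > 27000 nM in this assay, at which 3 of the 3 values shown sit, describes where every measured value sits. Within the data shown here, the single step between measured compounds, a step that the two limits leave unreadable from compound 2 to compound 3, cannot be read since both of its ends are limits. Compound 4 `CN1CCN(C(=O)C2CCN(C(=O)c3ccc(S(C)(=O)=O)c([N+](=O)[O-])c3)CC2)CC1` differs from compound 3 by 4-methylpiperazin-1-yl in place of (2-fluorobenzyl)(methyl)amino on a carbonyl carbon. No readable step bears on this exchange, so there is no measured basis for a change in either direction in this assay. The expectation for compound 4 is a number no higher from compound 3 to compound 4 (the limit leaves the size open), meaning no step beyond the scatter and most likely again a value reported only as a limit. Compound 4 is thus estimated at 27000 nM, with an expected range from 12000 nM to 27000 nM.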

Compound 4, half-maximal effective concentration: > 27000 nM
Compound 4: a limit, no number; the forecaster's own chance of this, stated with the estimate: 85%; the middle value lies on the limit itself.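

In this assay compound 4 gives > 27000 nM, a limit and not a number. Among these compounds, no step to compound 4 from compound 1, compound 2 or compound 3 can therefore be read. How these four compounds truly rank in this assay stays open, with every value at one limit: the limit of > 27000 nM in this assay, at which 4 of the 4 values shown sit.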